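Amine ring swap at the propoxy chain end

The source may report more compounds than this note shows. Statements on the series, on what has been measured and on what is new or still open speak of the compounds shown alone.

The series shares one core carrying a three-carbon chain, ending in a cyclic amine, on an oxygen of the aromatic system. Compound 1 `COc1cc2c(Oc3ccc(NC(=O)NN4C(=O)CSC4c4c(F)cccc4F)c(Cl)c3)ccnc2cc1OCCCN1CCCC1` gives 960 nM in a functional assay on A549 cells (Homo sapiens) for antiproliferative activity, read by MTT assay, with a stated time of 72 h; a higher number here means a weaker inhibitor, a lower number a stronger inhibitor. Compound 2 `COc1cc2c(Oc3c(F)cc(NC(=O)NN4C(=O)CSC4c4c(F)cccc4F)cc3F)ccnc2cc1OCCCN1CCCC1` gives 560 nM, and compound 3 `COc1cc2c(Oc3c(F)cc(NC(=O)NN4C(=O)C(C)SC4c4c(F)cccc4F)cc3F)ccnc2cc1OCCCN1CCCC1` gives 830 nM. Compound 2 sits at the low end of the three numbers, but its gaps to compound 3 and to compound 1 are both within the scatter, so the three cannot be told apart. Among the compounds with values here, the one single-point step, a 1.5-fold higher number from compound 2 to compound 3 (0.17 log units; within the scatter), concerns a methyl on a saturated ring carbon of the thiazolidinone and says nothing about the amine.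

Compound 4 `COc1cc2c(Oc3c(F)cc(NC(=O)NN4C(=O)CSC4c4c(F)cccc4F)cc3F)ccnc2cc1OCCCN1CCC(C)CC1` differs from compound 2 by 4-methylpiperidin-1-yl in place of pyrrolidin-1-yl on a saturated chain carbon, three bonds along the chain from an oxygen on an aromatic ring. Within the data shown here, no measured pair in this set alters the cyclic amine, so the step has no direct precedent here; the one change at a saturated carbon elsewhere, from compound 2 to compound 3, stayed within the scatter. On that basis a step of a 1.1-fold higher number from compound 2 to compound 4 (0.03 log units; within the scatter) in this assay is expected, that is none beyond the scatter, with no direction favoured. Compound 4 is therefore estimated at 600 nM, with a range from 250 nM to 1500 nM.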

Compound 4, half-maximal inhibitory concentration: 970 nM
Estimate against measurement, compound 4: 1.6-fold (0.21 log units) below, and the stated range covers the measured number.
By their numbers in this assay, from the lowest: compounds 2, 3, 1 and 4 (each within the scatter of the next).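

Within the data shown here, the step of a 1.7-fold higher number from compound 2 to compound 4 (0.24 log units; within the scatter) is the first reading at the chain end in this assay, and it places 4-methylpiperidin-1-yl and pyrrolidin-1-yl within the scatter of each other, so this assay cannot tell the two amines apart. The change on a saturated chain carbon, three bonds along the chain from an oxygen on an aromatic ring, therefore joins the methyl step on the saturated ring carbon as a single change without a readable effect, although here a five-membered non-aromatic ring gives way to a six-membered one carrying a methyl. No measurement available here accounts for the size of this step or bears on it.

The step changes ring size and adds the methyl together, so piperidin-1-yl would be needed to read the two apart. As far as these compounds go, whether any group at this chain end can move the number beyond the scatter remains open, for example morpholin-4-yl, 4-methylpiperazin-1-yl, dimethylamino, or the same amines on a shorter or longer chain.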